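The source may report more compounds than this note shows. Statements on the series, on what has been measured and on what is new or still open speak of the compounds shown alone.

In an ADME assay on HEK293 cells (Homo sapiens) for inhibition, read by MTT assay, with a stated time of 48 h (on this read-out higher numbers stand for weaker inhibition and lower numbers for stronger inhibition), compound 1 (`CCc1ccc(-c2nc3ccccn3c2Sc2ccccc2)cc1`) gives > 100000 nM as a limit of the assay and not a number. Compound 2 (`COc1ccc(-c2nc3ccccn3c2Sc2ccccc2)cc1`) gives > 100000 nM as a limit as well. Compound 3 (`c1ccc(Sc2c(-c3cccs3)nc3ccccn23)cc1`) gives > 100000 nM as a limit too, so its standing in the series is known only as that limit. Taken together, the series shows the limit of > 100000 nM in this assay, at which 3 of the 3 values shown sit, and no number has been read so far.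

Compound 4 (`c1ccc(Sc2c(-c3ccsc3)nc3ccccn23)cc1`) has thiophen-3-yl in place of thiophen-2-yl on an aromatic carbon. The change is thiophen-3-yl in place of thiophen-2-yl on an aromatic carbon and it sits next to the ring atom that bears a phenylsulfanyl group.

The measured steps that bear on it are a step that the two limits leave unreadable from compound 1 to compound 3 and a step that the two limits leave unreadable from compound 2 to compound 3 along with a step that the two limits leave unreadable from compound 1 to compound 2 and none of them offers a size to carry over. The expectation therefore rests on compound 3 at > 100000 nM as its limit, and no step beyond the scatter is expected in this assay in either direction. The expected outcome is a number no higher from compound 3 to compound 4 (the limit leaves the size open) as an estimate only. For compound 4 the estimated value is 100000 nM with an expected range from 50000 nM to 200000 nM and a report as a limit is the likely result.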

Compound 4, half-maximal inhibitory concentration: 91700 nM
The estimate for compound 4 lay 1.1-fold (0.04 log units) above the measured number, and the stated range covers the measured number.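

For the compounds shown here, compound 4, with thiophen-3-yl in place of thiophen-2-yl, is the first compound in this assay to give a readable number and not a limit, and the change at this position yields an at least 1.0-fold lower number from compound 3 to compound 4 (0.03 log units; that floor lies within the scatter). Replacing the phenyl-bearing groups at the same position gives the same floor, with an at least 1.0-fold lower number from compound 2 to compound 4 (0.03 log units; that floor lies within the scatter) and an at least 1.0-fold lower number from compound 1 to compound 4 (0.03 log units; that floor lies within the scatter), so none of the three steps is shown to lie beyond the scatter. The steps among compound 1, compound 2 and compound 3 cannot be read, and the series remains largely at its limit: the limit of > 100000 nM in this assay, at which 3 of the 4 values shown sit.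

As far as these compounds go, the true size of each step into compound 4 stays open, as compound 1, compound 2 and compound 3 each carry only a limit. Also open, from the compounds shown here alone, is whether an amine or a carboxylic acid in place of the thiophen-3-yl would move the number clearly away from that of compound 4.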